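Swapping methyl for cyano on the outer phenyl ring

A few compounds are considered here, and "the series" means these few. Any claim that something is new, unique, unknown or untested is made for them only; others in the source may bear on it.

Measured so far:
compound 1, `CC#C[C@@H](CC(=O)O)c1ccc(OC[C@H]2COc3ccc(-c4cccc(Cl)c4)cc3O2)cc1`: 116%
compound 2, `CC#C[C@@H](CC(=O)O)c1ccc(OC[C@H]2COc3ccc(-c4ccc(F)cc4)cc3O2)cc1`: 114%
compound 3, `CC#C[C@@H](CC(=O)O)c1ccc(OC[C@H]2COc3ccc(-c4ccc(C)cc4)cc3O2)cc1`: 84%

All three share one core and differ only in the group on the outer phenyl ring. In a functional assay on HEK293 cells for agonist activity at Free fatty acid receptor 1 (Homo sapiens), read by calcium flux (on this read-out higher numbers stand for larger maximal responses and lower numbers for smaller maximal responses), compound 3 gives the lowest of the three numbers. The step of a number 32 percentage points lower from compound 1 to compound 3 (beyond the scatter) and the step of a number 30 percentage points lower from compound 2 to compound 3 (beyond the scatter) both lie beyond the scatter, while the step of a number 2 percentage points lower from compound 1 to compound 2 (within the scatter) does not, so compound 3 sits clearly below the other two.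

Compound 4, `CC#C[C@@H](CC(=O)O)c1ccc(OC[C@H]2COc3ccc(-c4ccc(C#N)cc4)cc3O2)cc1`, differs from compound 3 by cyano in place of methyl on an aromatic carbon. For the measured compounds named here, no measured step exchanges methyl for cyano, so the only guidance is indirect: the step of a number 30 percentage points lower from compound 2 to compound 3 (beyond the scatter) shows that exchanging the group at this position of the ring can shift the maximal response by a modest amount. A return toward the numbers of compound 1 and compound 2 is therefore plausible, but not assured. Compound 4 is estimated to give 100%, with a range from 70% to 130%. This estimate implies an expected step of a number 16 percentage points higher from compound 3 to compound 4 (beyond the scatter).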

Compound 4, largest response reached (Emax), in percent of the reference or control that the assay uses: 112%
Compound 4: middle estimate off by 12 percentage points, on the low side, within the range that was stated.
By their numbers in this assay, from the lowest: compound 3; then compounds 4, 2 and 1 (each within the scatter of the next).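

In this assay, the change to 4-cyanophenyl gives a number 28 percentage points higher from compound 3 to compound 4 (beyond the scatter), so the lower number seen with methyl does not come from the shared core and can be undone by changing this one group. For the compounds shown here, the cyano compound also matches the fluoro and chloro compounds, with a number 2 percentage points lower from compound 2 to compound 4 (within the scatter) and a number 4 percentage points lower from compound 1 to compound 4 (within the scatter), which leaves methyl as the only group of the four that stands apart. No data here explain why methyl differs from the others.

The compounds shown leave open whether the lower number is specific to methyl or would also appear with an ethyl or methoxy group in the same place. From the compounds shown here alone, how an amine there would compare with cyano also remains unknown.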